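The compounds below may be only part of what the source reports. "The series", "measured", "known", "first", "only" and "open" are said of these compounds alone.

The measured compounds and their values in an ADME assay on microsomes from liver (Homo sapiens) for metabolic stability, with a stated time of 10 min; on this read-out higher numbers stand for a more stable compound and lower numbers for a less stable compound:

Compound 1 `O=C(NS(=O)(=O)c1ccccc1)c1ccc(Nc2nc(NC3(c4ccc(Cl)cc4)CC3)nc(OCC(F)(F)F)n2)cc1` gives 100%.
Compound 2 `CC(C)NC(=O)NCCS(=O)(=O)NC(=O)c1ccc(Nc2nc(NC3(c4ccc(Cl)cc4)CC3)nc(OCC(F)(F)F)n2)cc1` gives 100%.
Compound 3 `CN(C)S(=O)(=O)NC(=O)c1ccc(Nc2nc(NC3(c4ccc(Cl)cc4)CC3)nc(OCC(F)(F)F)n2)cc1` gives 86%.

Compound 1 stands level with compound 2 at the digits shown, and the two together hold the highest of the three numbers. Compound 3 lies lower, the step of a number 14 percentage points lower from compound 1 to compound 3 (beyond the scatter) being beyond the scatter, though modest.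

Compound 4 `NCCS(=O)(=O)NC(=O)c1ccc(Nc2nc(NC3(c4ccc(Cl)cc4)CC3)nc(OCC(F)(F)F)n2)cc1` has not yet been measured in this assay. It differs from compound 1 in one place: 2-aminoethyl in place of phenyl on a sulfonyl sulfur. Going by the values given here, two measured steps bear on this change, both of which replace the phenyl on the sulfonyl sulfur. The step of no change at the digits printed from compound 1 to compound 2 (within the scatter), where a chain enters, stays within the scatter. The step of a number 14 percentage points lower from compound 1 to compound 3 (beyond the scatter), where dimethylamino enters, is a modest fall. The third step, a number 14 percentage points lower from compound 2 to compound 3 (beyond the scatter), repeats that fall from the chain-bearing compound 2. Compound 4 carries a chain on the sulfonyl sulfur, as compound 2 does, so the closer parallel is the unchanged step; the fall seen for compound 3 marks how far a drop might reach.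

The step from compound 1 to compound 4 is therefore expected to be small, a number 5 percentage points lower from compound 1 to compound 4 (within the scatter), most likely within the scatter. Compound 4 is expected to give about 95%, within a range from 82% to 100%.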

Compound 4, percent of the compound remaining: 100%
Beside the measured number, compound 4's estimate is 5 percentage points below it, within the range that was stated.
By their numbers in this assay, from the lowest: compound 3; then compounds 1, 2 and 4 (each within the scatter of the next).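

In this assay, 2-aminoethyl in place of phenyl on the sulfonyl sulfur gives no change at the digits printed from compound 1 to compound 4 (within the scatter), so among the compounds shown, this position accepts a group with no ring and with a hydrogen-bond donor and acceptor without a change beyond the scatter. Hydrogen in place of isopropylcarbamoyl on the amine nitrogen of the chain gives no change at the digits printed from compound 2 to compound 4 (within the scatter), so the terminal urea of compound 2 is not needed to keep the number at this level, while a number 14 percentage points higher from compound 3 to compound 4 (beyond the scatter) leaves compound 3 alone at the low end of the four compounds. No evidence is available to explain why these three groups stand level or why the dimethylamino compound stands apart.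

As far as these compounds go, what remains open is whether the lower number of compound 3 goes with a nitrogen carried on the sulfonyl sulfur or with its two methyl groups, which a plain amino group or a 2-(dimethylamino)ethyl chain at the same place could separate. Also open, from the compounds shown here alone, is how a carboxylic acid at the end of the chain, or a longer chain ending in an amine, would read here.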